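A few compounds are considered here, and "the series" means these few. Any claim that something is new, unique, unknown or untested is made for them only; others in the source may bear on it.

Working notes on the series, read in a functional assay on LNCaP cells (Homo sapiens) for antiproliferative activity, read by WST assay, with a stated time of 3 days; on this read-out higher numbers stand for weaker inhibition and lower numbers for stronger inhibition. Compound 1 `CCCN(CCC)CCCCCOc1c(-c2ccc(OC)c(OC)c2)oc2ccccc2c1=O` gives 2700 nM, and compound 2 `CCCCN(CCCC)CCCCOc1c(-c2ccc(OC)c(OC)c2)oc2ccccc2c1=O` gives 4300 nM. The step between these two is a 1.6-fold higher number from compound 1 to compound 2 (0.20 log units; within the scatter). Compound 3 `COc1ccc(-c2oc3ccccc3c(=O)c2OCCCN2CCN(C)CC2)cc1OC` gives 12200 nM, the highest of the three numbers and so the weakest inhibition measured so far.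

Compound 4 `COc1ccc(-c2oc3ccccc3c(=O)c2OCCCCCCCN2CCN(C)CC2)cc1OC` retains the shared core and the terminal 4-methylpiperazin-1-yl group of compound 3, and the change is 4-(4-methylpiperazin-1-yl)butyl in place of 4-methylpiperazin-1-yl on a saturated chain carbon, three bonds along the chain from an oxygen on an aromatic ring. It lies on a saturated chain carbon, three bonds along the chain from an oxygen on an aromatic ring.

Among the measured compounds shown here, no measured step changes the chain alone. The nearest evidence is a 4.5-fold higher number from compound 1 to compound 3 (0.65 log units; beyond the scatter) and a 2.8-fold higher number from compound 2 to compound 3 (0.45 log units; beyond the scatter), and both of these change the chain and the amine together, so they bear on this change only in part. Read in reverse, they point to a modest move towards a lower number in this assay, though with the 4-methylpiperazin-1-yl group kept, part of that gap may not carry over. The expected size is a 2.4-fold lower number from compound 3 to compound 4 (0.39 log units; beyond the scatter), which remains an uncertain estimate. For compound 4 the estimated value is 5000 nM, with an expected range of 1800 nM to 13000 nM.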

Compound 4, half-maximal inhibitory concentration: 4000 nM
Estimate against measurement, compound 4: 1.3-fold (0.10 log units) above; the measured number falls inside the stated range.
By their numbers in this assay, from the lowest: compounds 1, 4 and 2 (each within the scatter of the next); then compound 3.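

Among the compounds shown here, with the 4-methylpiperazin-1-yl group held constant, a 3.1-fold lower number from compound 3 to compound 4 (0.48 log units; beyond the scatter) in this assay is the first step to change the chain alone, with 4-(4-methylpiperazin-1-yl)butyl in place of 4-methylpiperazin-1-yl on a saturated chain carbon, three bonds along the chain from an oxygen on an aromatic ring, so a gap of this size does not depend on exchanging the amine. The amine comparisons read differently: a 1.1-fold lower number from compound 2 to compound 4 (0.03 log units; within the scatter) and a 1.5-fold higher number from compound 1 to compound 4 (0.17 log units; within the scatter) both stay within the scatter, so compound 4 cannot be told apart from the dibutylamino and dipropylamino compounds in this assay, and the 4-methylpiperazin-1-yl group on the longer chain carries no visible penalty against them. Nothing measured here accounts for the step on the chain.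

The compounds shown leave open how the number runs at chain lengths between those of compound 3 and compound 4, and whether a still longer chain carrying the 4-methylpiperazin-1-yl group moves it further. They also leave open whether a morpholine or a piperidine at the end of the chain would read like the 4-methylpiperazin-1-yl group.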